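From methyl to hydrogen on an amide-type nitrogen

The source may report more compounds than this note shows. Statements on the series, on what has been measured and on what is new or still open speak of the compounds shown alone.

In a functional assay on thoracic aorta (Rattus norvegicus, strain Wistar), with a stated time of 15 min (a lower number here means that less compound is needed, a higher number that more compound is needed for the effect), compound 2 `CCOc1ccc(Cl)cc1C(C)NC(=O)N(C)S(=O)(=O)c1ccc(Cl)cc1` gives 14600 nM, the lower of the two actual numbers in this small set. Compound 3 `CCOc1ccc(Br)cc1C(C)NC(=O)N(C)S(=O)(=O)c1ccc(Cl)cc1` gives 55700 nM, and the step is a 3.8-fold higher number from compound 2 to compound 3 (0.58 log units; beyond the scatter). That step swaps bromo for chloro on an aromatic carbon, so it shows the size of a modest change elsewhere in the structure but does not measure the change considered here.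

Compound 4 `CCOc1ccc(Cl)cc1C(C)NC(=O)NS(=O)(=O)c1ccc(Cl)cc1` has hydrogen in place of methyl on an amide-type nitrogen. Among the compounds with values here, no measured step isolates this change. Within the data shown here, the nearest evidence is compound 1 `COc1ccc(Cl)cc1C(C)NC(=O)NS(=O)(=O)c1ccc(Cl)cc1`, the only measured compound with hydrogen on that nitrogen, and its > 300000 nM is a limit of the assay. On that basis, a sizeable step towards a higher number in this assay is expected, though its size remains uncertain, and compound 4 may also reach a limit.

The expected change is an 8.2-fold higher number from compound 2 to compound 4 (0.91 log units; beyond the scatter). Compound 4 is estimated at 120000 nM, with an expected range from 30000 nM to 450000 nM.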

Compound 4, half-maximal effective concentration: 281000 nM
The estimate for compound 4 lay 2.3-fold (0.37 log units) below the measured number, and the stated range covers the measured number.
By their numbers in this assay, from the lowest: compound 2; then compound 3; then compound 4. At a limit, above all of these: compound 1.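

A single pair now isolates the change from methyl to hydrogen on an amide-type nitrogen whose other neighbours are a carbonyl carbon and a sulfonyl sulfur, and in this assay it gives a large step: a 19-fold higher number from compound 2 to compound 4 (1.28 log units; beyond the scatter). On this position the change therefore counts for more than bromo in place of chloro on an aromatic carbon, which gave a 3.8-fold higher number from compound 2 to compound 3 (0.58 log units; beyond the scatter). The other new step, methyl in place of hydrogen on a saturated chain carbon bound to an oxygen on an aromatic ring, is an at least 1.0-fold lower number from compound 1 to compound 4 (0.02 log units; that floor lies within the scatter). This step cannot be read as a size, because the value of compound 1 is a limit: the limit of > 300000 nM in this assay, at which 1 of the 4 values shown sits.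

The compounds shown leave open whether an ethyl group or a longer chain on that nitrogen would give a number closer to that of compound 2 or further from it. On these data alone, they also rest this change on one pair, so whether it holds with bromo on the aromatic ring remains open.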